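From methyl to trifluoromethyl on an aromatic carbon

The compounds below may be only part of what the source reports. "The series", "measured", "known", "first", "only" and "open" are said of these compounds alone.

For the measured compounds named here, in a functional assay on MCF7 cells (Homo sapiens) for antiproliferative activity, read by MTT assay, with a stated time of 72 h (a higher number here means a weaker inhibitor, a lower number a stronger inhibitor), compound 2 (`CNc1nc(-c2cc(OC)c(OC)c(OC)c2)c(-c2ccc(C)cc2)s1`) gives 10.1 nM and holds the lower of the two numbers so far, while compound 1 (`CNc1nc(-c2cc(OC)c(OC)c(OC)c2)c(-c2ccc3ccccc3c2)s1`) gives 21.1 nM and sits beyond the scatter from it. Compound 3 (`CNc1nc(-c2cc(OC)c(OC)c(OC)c2)c(-c2ccc(C(F)(F)F)cc2)s1`) carries trifluoromethyl in place of methyl on an aromatic carbon, para to a large group (trifluoromethyl in place of methyl on an aromatic carbon). Going by the values given here, no measured pair shows this change, so the expectation is only tentative. A modest rise in the number is expected in this assay (a 2.5-fold higher number from compound 2 to compound 3 (0.39 log units; beyond the scatter)) although a step within the scatter remains possible. For compound 3 the estimated value is 25 nM (expected range 7 nM to 90 nM) in this series.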

Compound 3, half-maximal inhibitory concentration: 7290 nM
Compound 3: middle estimate off by 290-fold (2.46 log units), on the low side; measured number outside the range, above it.
By their numbers in this assay, from the lowest: compound 2; then compound 1; then compound 3.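

In this assay, replacing methyl with trifluoromethyl on this aromatic carbon, para to a large group, gives a 720-fold higher number from compound 2 to compound 3 (2.86 log units; beyond the scatter). For the compounds shown here, this single exchange shows that the number can move sharply at this position, which the earlier compounds did not reveal. Nothing measured here accounts for the size of this step.

Going by these compounds, whether chlorine, ethyl, methoxy or an amine at this carbon would keep the number close to that of compound 2 stays open. Also open, on these data alone, is whether the loss is specific to trifluoromethyl.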